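Taking Both Fluorines off the Benzyl Group

The source may hold more compounds than are shown below. What is called first, only, known or untested is meant among the compounds shown, and "the series" means these compounds.

Compound 3 `Fc1ccc(Cn2cc(CCCOc3cccc4cccnc34)nn2)cc1F` gives 8.5 ug/mL in a functional assay on 786-0 cells (Homo sapiens) for inhibition, read by sulforhodamine B assay, with a stated time of 48 h; on this read-out lower numbers stand for stronger inhibition of growth and higher numbers for weaker inhibition of growth. Among the three measured numbers it stands second highest: compound 2 `FC(F)(F)Oc1ccc(Cn2cc(CCCOc3cccc4cccnc34)nn2)cc1` with 7.9 ug/mL sits within the scatter of it, whereas compound 1 `Fc1ccc(Cn2cc(CCCOc3cccc4cccnc34)nn2)cc1` with 195 ug/mL is far off. That gap is described by a 23-fold lower number from compound 1 to compound 3 (1.36 log units; beyond the scatter), a large step.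

Compound 4 `c1ccc(Cn2cc(CCCOc3cccc4cccnc34)nn2)cc1` differs from compound 3 in one place: phenyl in place of 3,4-difluorophenyl on a saturated chain carbon bound to an aromatic nitrogen. The step that bears on this most directly is a 23-fold lower number from compound 1 to compound 3 (1.36 log units; beyond the scatter), since it is the reverse of part of the present change; the other measured step, a 25-fold lower number from compound 1 to compound 2 (1.39 log units; beyond the scatter), concerns a different replacement and bears only loosely on it. Going by the values given here, removing the second fluorine as well has no measured counterpart here. Because a 23-fold lower number from compound 1 to compound 3 (1.36 log units; beyond the scatter) was large, the reverse change is expected to undo most of that gain, so a large step toward a higher number in this assay is expected, a 24-fold higher number from compound 3 to compound 4 (1.37 log units; beyond the scatter). Compound 4 is therefore estimated to give 200 ug/mL, within 60 ug/mL to 600 ug/mL.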

Compound 4, concentration for 50% growth inhibition: 25 ug/mL
Beside the measured number, compound 4's estimate is 8.0-fold (0.90 log units) above it; measured number outside the range, below it.
By their numbers in this assay, from the lowest: compounds 2 and 3 (each within the scatter of the next); then compound 4; then compound 1.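

Taking both fluorines off costs far less than the single fluoro compound suggested, with a 2.9-fold higher number from compound 3 to compound 4 (0.47 log units; beyond the scatter) leaving the benzyl compound much nearer the 3,4-difluorobenzyl compound than compound 1 stands. The unsubstituted phenyl also shows that the single fluoro is the outlier, since a 7.8-fold lower number from compound 1 to compound 4 (0.89 log units; beyond the scatter) runs opposite to the drop seen on adding the second fluorine, so the number does not follow the count of fluorines in one direction, while a 3.2-fold higher number from compound 2 to compound 4 (0.50 log units; beyond the scatter) shows that the trifluoromethoxy compound also holds a modest edge over the plain benzyl. Nothing among the data shown accounts for this reversal.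

The compounds shown leave open whether a chloro or a methoxy group on the phenyl would follow compound 2 and compound 3 or compound 1. They also leave open whether a longer chain in place of the benzyl methylene would keep these differences.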